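One fluorine moved on the nitrophenyl group

The source may hold more compounds than are shown below. What is called first, only, known or untested is meant among the compounds shown, and "the series" means these compounds.

compound 1 `CC(C)(C)OC(=O)CCC(Nc1ccc(CN(CCCc2c(N)nc(N)nc2O)c2cc(F)cc(F)c2[N+](=O)[O-])cc1)C(=O)OC(C)(C)C` gives 13000 nM
compound 2 `Nc1nc(N)c(CCCNc2ccc([N+](=O)[O-])c(F)c2F)c(O)n1` gives 76000 nM

In a functional assay on CCRF-CEM cells (Homo sapiens) for cytotoxicity, in the absence of a further agent (a higher number here means a weaker inhibitor, a lower number a stronger inhibitor), compound 1 holds the lower of the two numbers, and compound 2 stands above it by more than the scatter. Compound 3 `CC(C)(C)OC(=O)CCC(Nc1ccc(CN(CCCc2c(N)nc(N)nc2O)c2cc(F)c(F)cc2[N+](=O)[O-])cc1)C(=O)OC(C)(C)C` has not yet been measured. It differs from compound 1 on an amine nitrogen, with 4,5-difluoro-2-nitrophenyl in place of 3,5-difluoro-2-nitrophenyl (4,5-difluoro-2-nitrophenyl in place of 3,5-difluoro-2-nitrophenyl on an amine nitrogen). Among the compounds with values here, no measured pair shows this change, so no step beyond the scatter is expected in this assay, in either direction. The expected step is small (a 1.1-fold lower number from compound 1 to compound 3 (0.03 log units; within the scatter)). For compound 3 the estimated value is 12000 nM (expected range 4000 nM to 36000 nM).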

Compound 3, half-maximal inhibitory concentration: 4800 nM
The estimate for compound 3 lay 2.5-fold (0.40 log units) above the measured number; low and high end bracket the measured number.
By their numbers in this assay, from the lowest: compound 3; then compound 1; then compound 2.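

In this assay the swap of 3,5-difluoro-2-nitrophenyl for 4,5-difluoro-2-nitrophenyl on an amine nitrogen gives a 2.7-fold lower number from compound 1 to compound 3 (0.43 log units; beyond the scatter) and so moves the number beyond the scatter, though the two compounds have the same atoms, joined differently. Within the data shown here, the placing of the fluorines on this ring therefore matters here, which no earlier pair could show. Nothing measured here explains the step.

On these data alone, it remains open whether the step persists with chlorine atoms in place of the fluorines, or with a nitrile in place of the nitro group. As far as these compounds go, it is also open whether it holds with free carboxylic acids in place of the esters.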